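The source may report more compounds than this note shows. Statements on the series, on what has been measured and on what is new or still open speak of the compounds shown alone.

- Compound 1 `CC1CCN(c2ccc(Nc3nccc(-c4ccco4)n3)cc2)CC1` reads 1800 nM
- Compound 2 `CC(=O)N(C)c1ccc(Nc2nccc(-c3ccccn3)n2)cc1` reads 1800 nM

Both compounds were measured in a functional assay for inhibition, with Homo sapiens as the target; on this read-out lower numbers stand for stronger inhibition and higher numbers for weaker inhibition. At the digits reported, compound 2 stands level with compound 1, and nothing separates them beyond the usual scatter of repeat measurements. The two differ in more than one place, so this pair cannot isolate the effect of any single change.

Compound 3 `CC1CCN(c2ccc(Nc3nccc(-c4ccccn4)n3)cc2)CC1` differs from compound 2 in one place: 4-methylpiperidin-1-yl in place of acetyl(methyl)amino on an aromatic carbon. Going by the values given here, no measured pair shows this swap alone. The entering group does already appear in compound 1, which gives 1800 nM in this assay despite its other difference from compound 2. Among the compounds with values here, that single reading offers the only guide, and it suggests no step beyond the scatter, with at most a slight shift towards stronger inhibition. The estimated change is a 1.2-fold lower number from compound 2 to compound 3 (0.08 log units; within the scatter) and would stay within the scatter. For compound 3 the expected value is 1500 nM with an estimated range of 500 nM to 4500 nM around it.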

Compound 3, half-maximal inhibitory concentration: 1900 nM
The estimate for compound 3 lay 1.3-fold (0.10 log units) below the measured number; measured number inside the range.
By their numbers in this assay, from the lowest: compounds 1, 2 and 3 (each within the scatter of the next).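

In this assay, 4-methylpiperidin-1-yl in place of acetyl(methyl)amino, on an aromatic carbon para to a large group, gives a 1.1-fold higher number from compound 2 to compound 3 (0.02 log units; within the scatter), so a non-aromatic ring and an open amide group cannot be told apart at this position. The second single swap, pyridin-2-yl in place of furan-2-yl on an aromatic carbon, gives a 1.1-fold higher number from compound 1 to compound 3 (0.02 log units; within the scatter), so these two aromatic groups cannot be told apart in this assay either. Compound 1 and compound 2 differ in more than one place and could not show either of these swaps alone, and nothing at hand explains why neither one moves the number beyond the scatter.

As far as these compounds go, all three compounds lie within the scatter of one another, so it remains open whether any group at these two places can shift the read-out at all. A primary amine or a carboxylic acid in place of 4-methylpiperidin-1-yl, or a plain phenyl ring in place of pyridin-2-yl, would test how far this lack of response extends.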